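Sulfonyl group on the ring nitrogen of compound 3

The source may hold more compounds than are shown below. What is called first, only, known or untested is meant among the compounds shown, and "the series" means these compounds.

Measured so far in a functional assay on HepG2 cells (Homo sapiens) for cytotoxicity, read by MTT assay, with a stated time of 24 h; on this read-out lower numbers stand for stronger inhibition and higher numbers for weaker inhibition:
compound 1 `COc1cc(/C=C2\CN(C)C/C(=C\c3cccnc3)C2=O)cc(OC)c1OC` gives 9520 nM
compound 2 `CN1C/C(=C\c2cccnc2)C(=O)/C(=C/c2ccc(F)cc2Br)C1` gives 13000 nM
compound 3 `O=C1/C(=C/c2cccnc2)CNC/C1=C\c1ccccc1F` gives 21000 nM

Compound 3 at 21000 nM lies within the scatter of compound 2 and carries a higher number than compound 1 by a margin beyond the scatter. On these data alone, compound 4 `Cc1ccc(S(=O)(=O)N2C/C(=C\c3cccnc3)C(=O)/C(=C/c3ccccc3F)C2)cc1` is untested and differs from compound 3 by (4-methylphenyl)sulfonyl in place of hydrogen on an amine nitrogen in a ring. Going by the values given here, no measured pair isolates a change at this nitrogen, so the expectation is loosely founded. A moderate move toward stronger inhibition is expected, an estimated 3.0-fold lower number from compound 3 to compound 4 (0.48 log units; beyond the scatter) in this assay overall. The estimate for compound 4 is 7000 nM (from 2500 nM to 18000 nM).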

Compound 4, half-maximal inhibitory concentration: 4200 nM
For compound 4 the middle estimate is 1.7-fold (0.22 log units) above the measured one; low and high end bracket the measured number.
By their numbers in this assay, from the lowest: compound 4; then compounds 1, 2 and 3 (each within the scatter of the next, the first and the last beyond it).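

In this assay, (4-methylphenyl)sulfonyl in place of hydrogen on the amine nitrogen in the ring gives a 5.0-fold lower number from compound 3 to compound 4 (0.70 log units; beyond the scatter). Going by these compounds alone, this is the first single-place change, and it shows that this nitrogen can carry a substituent with stronger, not weaker, inhibition. Nothing available explains the shift.

The compounds shown leave open whether the sulfonyl link or the 4-methylphenyl ring accounts for the step. A methanesulfonyl or a benzoyl group on the same nitrogen would separate these two parts.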